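A few compounds are considered here, and "the series" means these few. Any claim that something is new, unique, unknown or untested is made for them only; others in the source may bear on it.

Measured so far in a functional assay on CHO-K1 cells for antagonist activity at transient receptor potential cation channel subfamily V member 1 (Homo sapiens), read by FLIPR; on this read-out higher numbers stand for weaker inhibition and lower numbers for stronger inhibition:
compound 1, `CC(C(=O)NCc1ccc(C(F)(F)F)nc1N(C)C)c1ccc(NS(C)(=O)=O)c(F)c1`: 19.1 nM
compound 2, `CC(C(=O)NCc1ccc(C(F)(F)F)nc1N1CC=CCC1)c1ccc(NS(C)(=O)=O)c(F)c1`: 0.3 nM

Within the data shown here, compound 2 holds the lowest of the two numbers in this assay; the one measured step, a 64-fold lower number from compound 1 to compound 2 (1.80 log units; beyond the scatter), sets it apart from compound 1 by a wide margin. Compound 3, `CC(C(=O)NCc1ccc(C(F)(F)F)nc1N1CCCCCCC1)c1ccc(NS(C)(=O)=O)c(F)c1`, is not yet measured. It differs from compound 2 by a group of 8 heavy atoms (7 carbon, 1 nitrogen; one eight-membered non-aromatic ring with 1 hetero atom) in place of a group of 6 heavy atoms (5 carbon, 1 nitrogen; one six-membered non-aromatic ring with 1 hetero atom), on an aromatic carbon; the ring on the aromatic carbon next to the ring nitrogen thus gains two members and loses its double bond outside aromatic rings. Only a 64-fold lower number from compound 1 to compound 2 (1.80 log units; beyond the scatter) bears on this, and it concerns a change from no ring to a six-membered ring, not from one ring to a larger one. Among the measured compounds shown here, the large gain there gives no ground for a further gain, and no measured pair tests ring size. A small step is therefore expected for compound 3, a 3.3-fold higher number from compound 2 to compound 3 (0.52 log units; beyond the scatter), within or just beyond the scatter. Compound 3 is estimated at 1 nM, with a range of 0.2 nM to 6 nM.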

Compound 3, inhibition constant: 0.7 nM
For compound 3 the middle estimate is 1.4-fold (0.15 log units) above the measured one; the measured number falls inside the stated range.
By their numbers in this assay, from the lowest: compound 2; then compound 3; then compound 1.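

In this assay, the position on the aromatic carbon next to the ring nitrogen accepts a larger ring with only a modest loss, a 2.3-fold higher number from compound 2 to compound 3 (0.37 log units; beyond the scatter), so the six-membered ring with its double bond is not the only ring that gives a number far below that of the open-chain group. The eight-membered ring keeps most of the gain, a 27-fold lower number from compound 1 to compound 3 (1.44 log units; beyond the scatter), and the large drop therefore appears with both rings measured at this position, though only these two rings are shown. Nothing available accounts for either step.

Ring size and the loss of the double bond change together in the step to compound 3, so their shares cannot be separated. Piperidine would separate them, while pyrrolidine and morpholine at this position remain open as tests of a smaller ring and a ring oxygen.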